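Hydroxy on the shared core of compound 2

A few compounds are considered here, and "the series" means these few. Any claim that something is new, unique, unknown or untested is made for them only; others in the source may bear on it.

Among the measured compounds shown here, in a functional assay on HepG2 cells (Homo sapiens) for antiproliferative activity, read by MTT assay, with a stated time of 48 h (on this read-out higher numbers stand for weaker inhibition and lower numbers for stronger inhibition), compound 2 `COc1ccc(-c2c(Nc3ccc(C)c(O)c3)c3ccccc3oc2=O)cc1` gives 10200 nM, the lowest of the three numbers so far. Compound 1 `COc1ccc(-c2c(Nc3ccc(F)cc3)c3ccccc3oc2=O)cc1` gives 35500 nM, and compound 3 `COc1ccc(-c2c(Nc3cccc(C(F)(F)F)c3)c3ccccc3oc2=O)cc1` gives 66400 nM. The series shows a 3.5-fold lower number from compound 1 to compound 2 (0.54 log units; beyond the scatter) and a 6.5-fold higher number from compound 2 to compound 3 (0.81 log units; beyond the scatter), both beyond the scatter, while a 1.9-fold higher number from compound 1 to compound 3 (0.27 log units; within the scatter) stays within it.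

All three steps exchange the aryl group on the nitrogen. Compound 4 `COc1ccc(-c2c(Nc3ccc(C)c(O)c3)c3ccc(O)cc3oc2=O)cc1` keeps the 3-hydroxy-4-methylphenyl group of compound 2 and differs elsewhere: hydroxy in place of hydrogen on an aromatic carbon, with hydroxy in place of hydrogen on an aromatic carbon of the shared core. For the measured compounds named here, no measured step touches that place, so the data give no direct guide to direction. The largest step at the nitrogen, a 6.5-fold higher number from compound 2 to compound 3 (0.81 log units; beyond the scatter), serves only as a rough bound on size.

No shift beyond the scatter is therefore expected, and the estimated 1.3-fold lower number from compound 2 to compound 4 (0.11 log units; within the scatter) reflects this. In this assay, the estimate for compound 4 is 8000 nM, with an expected range of 2500 nM to 25000 nM.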

Compound 4, half-maximal inhibitory concentration: > 75300 nM
Compound 4 was reported as a limit (the forecaster's own chance of this, stated with the estimate: 5%); at least 9.4-fold (0.97 log units) between middle value and limit.
By their numbers in this assay, from the lowest: compound 2; then compounds 1 and 3 (each within the scatter of the next). At a limit, above all of these: compound 4.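

This position on the shared core, an aromatic carbon of a six-membered aromatic ring of carbon only, part of a fused or bridged system of two rings, is not silent in this assay: hydroxy in place of hydrogen there gives an at least 7.3-fold higher number from compound 2 to compound 4 (0.86 log units; beyond the scatter). A change at the core can therefore move the number beyond the scatter, on a scale similar to the largest exchange of the aryl group on the nitrogen, a 6.5-fold higher number from compound 2 to compound 3 (0.81 log units; beyond the scatter). Compound 4 stands as a limit, > 75300 nM, and not as a number, so only the direction and a minimum size of the step can be read.

Only hydrogen and hydroxy are shown at this position, which leaves an amine or a carboxylic acid there without a reading. Also open, as far as these compounds go, is whether the step holds with 4-fluorophenyl or 3-(trifluoromethyl)phenyl on the nitrogen.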